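A few compounds are considered here, and "the series" means these few. Any claim that something is new, unique, unknown or untested is made for them only; others in the source may bear on it.

Working notes on the series.

Compound 1 `COc1ccc(-c2nc(SCC(=O)c3sc(-c4ccccc4)nc3C)[nH]c(=O)c2C#N)cc1`, compound 2 `Cc1nc(-c2ccccc2)sc1C(=O)CSc1nc(-c2ccc(Cl)c(Cl)c2)c(C#N)c(=O)[nH]1` and compound 3 `COc1ccc(-c2nc(SCC(=O)c3sc(-c4ccccc4)nc3C)[nH]c(=O)c2C#N)cc1OC` have been run in an ADME assay on HEK293 cells (Homo sapiens) for cytotoxicity, read by MTT assay, with a stated time of 48 h; on this read-out higher numbers stand for weaker inhibition and lower numbers for stronger inhibition. In this assay compound 1 gives 76200 nM, compound 2 gives 85100 nM and compound 3 gives 91800 nM. The steps between them are a 1.1-fold higher number from compound 1 to compound 2 (0.05 log units; within the scatter), a 1.2-fold higher number from compound 1 to compound 3 (0.08 log units; within the scatter) and a 1.1-fold higher number from compound 2 to compound 3 (0.03 log units; within the scatter); none of these separates the compounds from one another.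

Compound 4 `COc1ccc(-c2nc(C)c(C(=O)CSc3nc(-c4ccc(Cl)c(Cl)c4)c(C#N)c(=O)[nH]3)s2)cc1` is not yet measured in this assay. The cores of compound 2 and compound 1 differ by 3,4-dichlorophenyl in place of 4-methoxyphenyl on an aromatic carbon. The change from compound 2 to compound 4 is methoxy in place of hydrogen on an aromatic carbon. The same kind of change has been measured once, from compound 1 to compound 3, as methoxy in place of hydrogen on an aromatic carbon; there the entering group stands ortho to a methoxy group and meta to a large group, whereas in compound 4 it stands para to a large group, so the two changes are of the same kind rather than the same.

The measured step for this kind of change, a 1.2-fold higher number from compound 1 to compound 3 (0.08 log units; within the scatter), lies within the scatter. On that basis the expected step is a 1.1-fold higher number from compound 2 to compound 4 (0.05 log units; within the scatter), which is expected to stay within the scatter as well, resting on compound 2 at 85100 nM and on the step of a 1.2-fold higher number from compound 1 to compound 3 (0.08 log units; within the scatter). Compound 4 is therefore expected to give 95000 nM, estimated between 55000 nM and 165000 nM.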

Compound 4, half-maximal inhibitory concentration: 45600 nM
Estimate against measurement, compound 4: 2.1-fold (0.32 log units) above; measured number outside the range, below it.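

In this assay the new step, a 1.9-fold lower number from compound 2 to compound 4 (0.27 log units; within the scatter), lies within the scatter, as does the earlier step, a 1.2-fold higher number from compound 1 to compound 3 (0.08 log units; within the scatter), and the two cannot be told apart: the same change on two cores in this assay, a 1.2-fold higher number (0.08 log units; within the scatter) from compound 1 to compound 3 and a 1.9-fold lower number (0.27 log units; within the scatter) from compound 2 to compound 4, 2.2-fold (0.35 log units) apart, within the scatter of two such steps. Methoxy in place of hydrogen on an aromatic carbon has therefore not been shown to behave differently on the two cores, and neither step separates the compounds it joins. Going by these compounds alone, this does not show that the change carries over unaltered from one core to another, since the comparison rests on only two steps, the entering methoxy stands para to a large group only in compound 4, and a real dependence on the core that is no larger than the scatter would pass unseen here.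

The compounds shown leave open whether a different group in the position taken by methoxy in compound 4, such as an amine or a carboxylic acid, would give a step beyond the scatter in this assay. They also leave open whether a longer chain there, such as ethoxy or butoxy, would do so, and whether the methoxy change would read the same on further cores.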